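Fluoro on the phenyl of a quinoline-free name: compound 4

This account rests on a few compounds, and the source may have more. Where it says the series, first, only, none or still open, it means among the compounds named here.

Measured so far:
- compound 1, `CCCc1cc2ccccc2nc1-c1cc(-c2ccccc2)no1`: 47200 nM
- compound 2, `CCCCc1cc2ccccc2nc1-c1cc(-c2ccccc2)no1`: > 100000 nM
- compound 3, `CCCCCc1cc2ccccc2nc1-c1cc(-c2ccccc2)no1`: > 100000 nM

Compound 1 is the only one of the three with a numeric result in a functional assay on MDA-MB-231 cells (Homo sapiens) for inhibition, read by MTT assay, with a stated time of 24 h (on this read-out higher numbers stand for weaker inhibition and lower numbers for stronger inhibition), where compound 1 gives 47200 nM. For compound 2 the value > 100000 nM is a limit of the assay and not a number. For compound 3 the value > 100000 nM is likewise a limit. From the compounds shown here alone, compound 2 thus sits at the limit of > 100000 nM in this assay, at which 2 of the 3 values shown sit, so its true position beyond that point is unknown. The measured steps are an at least 2.1-fold higher number from compound 1 to compound 2 (0.32 log units; beyond the scatter) and an at least 2.1-fold higher number from compound 1 to compound 3 (0.32 log units; beyond the scatter), both lengthening the chain, while a step that the two limits leave unreadable from compound 2 to compound 3.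

Compound 4, `CCCCc1cc2ccccc2nc1-c1cc(-c2ccc(F)cc2)no1`, differs from compound 2 by fluoro in place of hydrogen on an aromatic carbon. Among the measured compounds shown here, no measured step touches this phenyl ring, so nothing here says how a fluoro at that place moves the number. For the measured compounds named here, the only anchor is that compound 2 itself shows a limit. Compound 4 is therefore expected to give 150000 nM, in the range 40000 nM to 600000 nM, with the step that the limit leaves unreadable from compound 2 to compound 4 expected to stay within the scatter, and most likely the assay again reports only a limit.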

Compound 4, half-maximal inhibitory concentration: 24200 nM
Estimate against measurement, compound 4: 6.2-fold (0.79 log units) above, outside the stated range (below it).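

In this assay, among the compounds shown here, changing phenyl to 4-fluorophenyl gives an at least 4.1-fold lower number from compound 2 to compound 4 (0.61 log units; beyond the scatter), so this ring, which stayed the same in the earlier compounds, is a place where a single added atom can move the number beyond the scatter. Until now only the chain had varied, and both lengthened chains ended at a limit. The chain of compound 2 stays in place in compound 4, and compound 4 still returns a real number, 24200 nM. Compound 2 gives > 100000 nM, which is a limit of the assay and not a number, so the step has a known minimum but no known full size: the limit of > 100000 nM in this assay, at which 2 of the 4 values shown sit.

The compounds shown do not tell whether this shift belongs to fluoro in particular or whether another group on the same ring carbon, such as chloro, methoxy or an amine, would move the number as well. They also leave open whether fluoro at this place would act in the same way on the chains of compound 1 and compound 3, and how far a still longer chain would be tolerated with the 4-fluorophenyl in place.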